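This account rests on a few compounds, and the source may have more. Where it says the series, first, only, none or still open, it means among the compounds named here.

Measured compounds:
Compound 1, `CCc1cc(N)c2cc(NC(=O)/C=C/c3ccc(C(F)(F)F)cc3)ccc2n1`: 1.2 nM
Compound 2, `CCCc1cc(N)c2cc(NC(=O)/C=C/c3ccc(O)cc3)ccc2n1`: 1100 nM

In an assay on isolated protein for displacement of a labelled ligand from melanin-concentrating hormone receptor 1 (Homo sapiens) (on this read-out lower numbers stand for stronger inhibition and higher numbers for weaker inhibition), compound 1 gives 1.2 nM, the lowest of the two numbers recorded. The structures of compound 1 and compound 2 are not alike in a single place only. In this assay compound 2 gives 1100 nM, a gap well beyond the scatter of repeated measurements. Among the measured compounds shown here, no pair of measured compounds differs in only one place, so no single step has been characterised, and nothing can be said of the effect of any one change on its own.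

Compound 3, `CC(C)c1cc(N)c2cc(NC(=O)/C=C/c3ccc(C(F)(F)F)cc3)ccc2n1`, departs from compound 1 by methyl in place of hydrogen on a saturated chain carbon bound to an aromatic carbon and a saturated chain carbon. This is a small addition at the edge of the molecule, far from the part that distinguishes compound 1 from compound 2, and the two measured numbers offer no guide to its effect. Compound 3 is therefore expected to stay close to compound 1, with a step of a 1.3-fold higher number from compound 1 to compound 3 (0.12 log units; within the scatter) that falls within the scatter in either direction. For compound 3 the estimate in this assay is 1.6 nM, in a range from 0.5 nM to 5 nM.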

Compound 3, half-maximal inhibitory concentration: 2.1 nM
For compound 3 the middle estimate is 1.3-fold (0.12 log units) below the measured one; the measured number falls inside the stated range.
By their numbers in this assay, from the lowest: compounds 1 and 3 (each within the scatter of the next); then compound 2.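

In this assay, among the compounds shown here, the change from ethyl to isopropyl gives the first step in one place only, and the step, a 1.8-fold higher number from compound 1 to compound 3 (0.24 log units; within the scatter), lies within the scatter, so compound 1 and compound 3 cannot be told apart. A methyl in place of hydrogen on a saturated chain carbon bound to an aromatic carbon and a saturated chain carbon therefore leaves the number in the same low range, which the earlier pair, differing in more than one place, could not show. No measurement at hand bears on the reason for this result.

On these data alone, whether this position also accepts a tert-butyl group, a cyclopropyl ring or a chain ending in an amine remains open. So does how much of the gap between compound 1 and compound 2 belongs to the trifluoromethyl and how much to the chain.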